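Aryl swap on a saturated ring carbon: working notes

This account rests on a few compounds, and the source may have more. Where it says the series, first, only, none or still open, it means among the compounds named here.

Compound 1 `CC1=C(C(=O)OCC(C)C)C(c2ccoc2)NC(=O)N1C` is the reference of the set. In an assay on membranes from HeLa cells for displacement of a labelled ligand from adenosine receptor A3 (Homo sapiens), read by scintillation counting, with a stated time of 180 min, tested at 1 uM (on this read-out higher numbers stand for more inhibition at the one concentration tested (going by the name of the read-out) and lower numbers for less inhibition), compound 1 gives 16%. Compound 2 `CC1=C(C(=O)OCC(C)C)C(c2cccs2)NC(=O)N1C` carries the change thiophen-2-yl in place of furan-3-yl on a saturated ring carbon and in this assay compound 2 gives 5%; the step is a number 11 percentage points lower from compound 1 to compound 2 (beyond the scatter). Compound 3 `CCC(CC)OC(=O)C1=C(C)NC(=O)NC1c1ccoc1` has the same atoms as compound 1 joined differently; the difference between the two cores is not broken down here. In this assay compound 3 gives 5%, level with compound 2 at the digits reported, and together the two sit lowest of the three numbers, with compound 1 higher by a margin beyond the scatter.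

Compound 4 `CCC(CC)OC(=O)C1=C(C)NC(=O)NC1c1cccs1` is not yet measured. It stands to compound 3 as compound 2 stands to compound 1, through the change (thiophen-2-yl in place of furan-3-yl on a saturated ring carbon). The surroundings are told differently in the two cases: on the core of compound 1 the neighbouring ring atom bears an isobutoxycarbonyl group and the place is also three ring bonds from the ring atom that bears a methyl group, whereas on the core of compound 3 the neighbouring ring atom bears a group of 8 heavy atoms; the change is therefore of the same kind, not the same. The earlier step of a number 11 percentage points lower from compound 1 to compound 2 (beyond the scatter) was downward and modest. For compound 4 the step expected is a number 2 percentage points lower from compound 3 to compound 4 (within the scatter), small because a read-out already at the level of compound 3 at 5% cannot fall by the earlier amount. Compound 4 is thus expected near 3%, between -5% and 12%.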

Compound 4, a percentage reported as inhibition, at one concentration (the size of the read-out at that concentration, not a potency): 1%
Beside the measured number, compound 4's estimate is 2 percentage points above it; measured number inside the range.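

In this assay, the change from furan-3-yl to thiophen-2-yl on the core of compound 3 gives a number 4 percentage points lower from compound 3 to compound 4 (within the scatter), and the two cores cannot be told apart on the size of this change: the same change on two cores in this assay, a number 11 percentage points lower (beyond the scatter) from compound 1 to compound 2 and a number 4 percentage points lower (within the scatter) from compound 3 to compound 4, 7 percentage points apart, within the scatter of two such steps

Going by these compounds alone, both steps point the same way, but only the step on the core of compound 1 lies beyond the scatter, so the step on the core of compound 3 does not confirm a loss on its own. The two pairs are compatible with the change carrying across these two cores, but they do not show that its size is the same on both, and a single concentration gives no measure of potency or of how the change would behave on any other core.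

The compounds shown hold only furan-3-yl and thiophen-2-yl on the saturated ring carbon, so it remains open how a phenyl ring, a pyridine ring or thiophen-3-yl would read there. Also open, from the compounds shown here alone, is whether a carboxylic acid or a longer chain in place of the isobutoxycarbonyl group would alter the effect of the aryl swap.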